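Working notes: from compound 2 to compound 3

The source may report more compounds than this note shows. Statements on the series, on what has been measured and on what is new or still open speak of the compounds shown alone.

Compound 1, `CCNC(=O)c1noc(-c2cc(C(C)C)c(O)cc2O)c1-c1cc(CO)no1`, gives 5 nM in a functional assay on A2780 cells (Homo sapiens) for inhibition; a lower number here means a stronger inhibitor, a higher number a weaker inhibitor.
Compound 2, `CCNC(=O)c1noc(-c2cc(C(C)C)c(O)cc2O)c1-c1cc(CN)no1`, has "not determined" (no result reported) in this assay.

Compound 2 stands nowhere on the numbers: its value in this assay was not determined, so only compound 1 anchors the series. Compound 3, `CCNC(=O)c1noc(-c2cc(C(C)C)c(O)cc2O)c1-c1cc(C(=O)O)no1`, differs from compound 2 by carboxy in place of aminomethyl on an aromatic carbon. For the measured compounds named here, no step between two measured compounds is available to size this change, and the move from compound 2 to compound 3 cannot be scored against the scatter. Taking the value of compound 1 as the only reference, a moderate loss is expected, beyond the scatter, and compound 3 is estimated at 50 nM, within 5 nM to 500 nM.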

Compound 3, half-maximal inhibitory concentration: 20000 nM
Beside the measured number, compound 3's estimate is 400-fold (2.60 log units) below it, outside the stated range (above it).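

This carbon of the five-membered aromatic ring, next to the ring nitrogen, does not tolerate every small group: in this assay, carboxy in place of hydroxymethyl gives a 4000-fold higher number from compound 1 to compound 3 (3.60 log units; beyond the scatter), a large step beyond the scatter. Compound 1 alone could not show how much depends on this substituent. The compounds shown offer no measured explanation for the step.

Steps involving compound 2 cannot be read, so the effect of aminomethyl here remains unknown. A carboxamide, a methyl ester or a longer hydroxyalkyl chain at this carbon would help define which features of the carboxy and hydroxymethyl groups separate these results.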